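From fluoro to methoxy at the assay limit

The source may report more compounds than this note shows. Statements on the series, on what has been measured and on what is new or still open speak of the compounds shown alone.

Measured in a toxicity assay on MCF7 cells (Homo sapiens) for cytotoxicity, read by MTT assay; on this read-out lower numbers stand for stronger inhibition of growth and higher numbers for weaker inhibition of growth:
Compound 1 `C/C(=N\NC(N)=S)c1sc(C)nc1C`: > 100 ug/mL
Compound 2 `C/C(=N\Nc1nc(-c2ccc(F)cc2)cs1)c1sc(C)nc1C`: > 100 ug/mL
Compound 3 `C/C(=N\Nc1nc(-c2ccc(F)cc2)cs1)c1sc(-c2ccccc2)nc1C`: > 100 ug/mL

All three entries are limits of the assay and not numbers. The set as a whole is summed up by the limit of > 100 ug/mL in this assay, at which 3 of the 3 values shown sit. Compound 3 therefore stands at > 100 ug/mL, a limit like the others.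

Compound 4 `COc1ccc(-c2csc(N/N=C(\C)c3sc(-c4ccccc4)nc3C)n2)cc1` follows from compound 3 by one change, (methoxy in place of fluoro on an aromatic carbon), which is methoxy in place of fluoro on an aromatic carbon, so that 4-fluorophenyl becomes 4-methoxyphenyl. Within the data shown here, the only measured step is a step that the two limits leave unreadable from compound 2 to compound 3. That step concerns phenyl in place of methyl on an aromatic carbon, not the group changed here, and it gives no size to carry over. Among the measured compounds shown here, no measured step sets a direction for this change, so no step beyond the scatter is expected in this assay. The estimated step is a number no higher from compound 3 to compound 4 (the limit leaves the size open). For compound 4 the expected value is 100 ug/mL, with an estimated range from 30 ug/mL to 200 ug/mL.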

Compound 4, concentration for 50% growth inhibition: > 100 ug/mL
Compound 4 was reported as a limit; the forecaster's own chance of this, stated with the estimate: 65%; the middle value sits exactly at the limit.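

Compound 3 and compound 4 both stand as limits of the assay and not as numbers, so no step between them can be read: the limit of > 100 ug/mL in this assay, at which 4 of the 4 values shown sit.

The compounds shown leave open whether 4-fluorophenyl and 4-methoxyphenyl differ at all in this assay, and what any of the four compounds would read as a number.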